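The source may report more compounds than this note shows. Statements on the series, on what has been measured and on what is new or still open speak of the compounds shown alone.

Measured in a functional assay on HCT-116 cells (Homo sapiens) for antiproliferative activity, read by MTT assay, with a stated time of 72 h; a higher number here means a weaker inhibitor, a lower number a stronger inhibitor:

- Compound 1 `O=C(CCc1cccc2c1B(O)OC2)Nc1cccc(-c2cccc(Cl)c2)c1` gives 350 nM
- Compound 2 `O=C(CCc1cccc2c1B(O)OC2)Nc1cccc(-c2ccc(Cl)cc2)c1` gives 380 nM
- Compound 3 `O=C(CCc1cccc2c1B(O)OC2)Nc1cccc(-c2cccc(OC(F)(F)F)c2)c1` gives 310 nM

All three values lie within the scatter of one another, so compound 3 holds no distinct place among them. The next compound, compound 4 `CC(=O)c1cccc(-c2cccc(NC(=O)CCc3cccc4c3B(O)OC4)c2)c1`, has acetyl in place of trifluoromethoxy on an aromatic carbon, meta to a large group: acetyl in place of trifluoromethoxy on an aromatic carbon.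

The closest measured change is a 1.1-fold lower number from compound 1 to compound 3 (0.05 log units; within the scatter), with trifluoromethoxy in place of chloro on an aromatic carbon. The other is a 1.1-fold higher number from compound 1 to compound 2 (0.04 log units; within the scatter), with 4-chlorophenyl in place of 3-chlorophenyl. Both lie within the scatter, so the series has so far shown little response to changes at this end of the molecule. Going by the values given here, no measured compound carries acetyl, however, so this expectation rests on indirect evidence and the range is kept wide. No step beyond the scatter is expected in this assay, and the expected change is a 1.3-fold higher number from compound 3 to compound 4 (0.11 log units; within the scatter). For compound 4 the estimated value is 400 nM, with an expected range from 180 nM to 900 nM.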

Compound 4, half-maximal inhibitory concentration: 86 nM
For compound 4 the middle estimate is 4.7-fold (0.67 log units) above the measured one; the whole stated range lies above it.
By their numbers in this assay, from the lowest: compound 4; then compounds 3, 1 and 2 (each within the scatter of the next).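

In this assay, this position on the aromatic ring had shown no step beyond the scatter between chloro and trifluoromethoxy, but it does respond to acetyl, both in place of trifluoromethoxy (a 3.6-fold lower number from compound 3 to compound 4 (0.56 log units; beyond the scatter)) and in place of chloro (a 4.1-fold lower number from compound 1 to compound 4 (0.61 log units; beyond the scatter)). The change from 4-chlorophenyl to 3-acetylphenyl also goes beyond the scatter (a 4.4-fold lower number from compound 2 to compound 4 (0.65 log units; beyond the scatter)), so compound 4 stands apart from all three other compounds. No measurement shown here accounts for this difference between acetyl and the other groups.

On these data alone, whether the step belongs to the carbonyl alone remains open, as a methyl ester or a primary amide at this position could show. Also open, as far as these compounds go, is whether a longer chain such as propanoyl, or a carboxylic acid, would give a similar number.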